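Side-chain swap from compound 3 to compound 4

This account rests on a few compounds, and the source may have more. Where it says the series, first, only, none or still open, it means among the compounds named here.

Measured in a physicochemical assay for lipophilicity; on this read-out higher numbers stand for higher lipophilicity and lower numbers for lower lipophilicity:
- compound 1 `C=C(C)COC[n+]1ccn(C)c1/C=N/O` gives -1.83
- compound 2 `C=CCCOC[n+]1ccn(C)c1/C=N/O` gives -1.84
- compound 3 `C=C(C)CCOC[n+]1ccn(C)c1/C=N/O` gives -1.41

Compound 3 stands highest of the three, at -1.41 on this scale, and its steps from both others lie beyond the scatter. The next compound, not yet measured, is compound 4 `C#CC(C)OC[n+]1ccn(C)c1/C=N/O`. The change is 1-methylprop-2-yn-1-yl in place of 3-methylbut-3-en-1-yl on an oxygen on a saturated carbon.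

Among the measured compounds shown here, two measured steps bear on this most directly. One is a number 0.43 log units higher from compound 2 to compound 3 (beyond the scatter) for methyl in place of hydrogen on a double-bonded chain carbon bound to a saturated chain carbon. The other is a number 0.42 log units higher from compound 1 to compound 3 (beyond the scatter) for 2-methylprop-2-en-1-yl in place of 1-methylethenyl on a saturated chain carbon bound to an oxygen on a saturated carbon. The remaining step, a number 0.01 log units lower from compound 1 to compound 2 (within the scatter) in size, offers no guide to direction. The entering group is the smaller by the count above, and both informative steps rise into compound 3, so a fall of similar or slightly larger size is expected. For the measured compounds named here, no measured compound carries a triple bond, which keeps the range wide. A lower number is expected in this assay with a number 0.54 log units lower from compound 3 to compound 4 (beyond the scatter) as the estimated step. Compound 4 is estimated at -1.95 within an expected range from -2.35 to -1.6 on this read-out.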

Compound 4, distribution coefficient: -2.14
Compound 4: the middle estimate sits 0.19 log units above what was measured; the measured number falls inside the stated range.
By their numbers in this assay, from the lowest: compounds 4, 2 and 1 (each within the scatter of the next, the first and the last beyond it); then compound 3.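

Among the compounds shown here, putting 1-methylprop-2-yn-1-yl in place of 3-methylbut-3-en-1-yl gives a number 0.73 log units lower from compound 3 to compound 4 (beyond the scatter) in this assay, the largest step among the compounds so far, and the first read for a chain with a triple bond on an oxygen on a saturated carbon. Against the two other chains the outcome is less clear: in place of 2-methylprop-2-en-1-yl the change gives a number 0.31 log units lower from compound 1 to compound 4 (beyond the scatter) and in place of but-3-en-1-yl it gives a number 0.30 log units lower from compound 2 to compound 4 (within the scatter), so the side of the scatter differs although compound 1 and compound 2 themselves lie within the scatter of each other. No measurement in hand accounts for these steps.

The swap from compound 3 to compound 4 alters the heavy-atom count, the branching and the kind of multiple bond together, so the share of each in the step remains unresolved. From the compounds shown here alone, an unbranched but-3-yn-1-yl chain, a saturated butyl chain or a longer chain ending in a triple bond would separate these features, and how a hydroxyl or an amine on the chain would read on this scale also remains open.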